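The source may report more compounds than this note shows. Statements on the series, on what has been measured and on what is new or still open speak of the compounds shown alone.

In a functional assay on CCRF-CEM cells for antagonist activity at C-X-C chemokine receptor type 4 (Homo sapiens), read by calcium flux, with stated times of 25 min and 90 s (a lower number here means a stronger inhibitor, a higher number a weaker inhibitor), compound 3 `CN1CCN(c2cccc3c2C[C@H](CN(C)[C@H]2CCCc4cccnc42)N(C)C3)CC1` gives 171 nM, the second highest of the three numbers: compound 1 `CN(C[C@H]1Cc2c(cccc2N2CCN(C3COC3)CC2)CN1)[C@H]1CCCc2cccnc21` gives 381 nM, and compound 2 `CN(C[C@H]1Cc2c(cccc2N2CCNCC2)CN1)[C@H]1CCCc2cccnc21` gives 6.08 nM. Compound 4 `CN1CCN(c2cccc3c2C[C@H](CN(C)[C@H]2CCCc4cccnc42)NC3)CC1` differs from compound 3 by hydrogen in place of methyl on an amine nitrogen in a ring. Among the measured compounds shown here, the only measured step of a similar kind, removing a group from a ring amine nitrogen, is a 63-fold lower number from compound 1 to compound 2 (1.80 log units; beyond the scatter), though it sits on a different nitrogen and so bears only loosely. A lower number is therefore expected for compound 4, but a smaller shift, estimated as a 2.9-fold lower number from compound 3 to compound 4 (0.45 log units; beyond the scatter). The estimate for compound 4 in this assay is 60 nM, with a range from 15 nM to 250 nM.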

Compound 4, half-maximal inhibitory concentration: 29.6 nM
The estimate for compound 4 lay 2.0-fold (0.31 log units) above the measured number, and the stated range covers the measured number.
By their numbers in this assay, from the lowest: compound 2; then compound 4; then compound 3; then compound 1.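

In this assay, the ring amine nitrogen next to the ring atom that bears a large group now has a measured effect: exchanging its methyl for hydrogen lowers the number modestly (a 5.8-fold lower number from compound 3 to compound 4 (0.76 log units; beyond the scatter)). On the other ring amine nitrogen, methyl gives a higher number than hydrogen (a 4.9-fold higher number from compound 2 to compound 4 (0.69 log units; beyond the scatter)), yet a much lower one than oxetan-3-yl (a 13-fold lower number from compound 1 to compound 4 (1.11 log units; beyond the scatter)). Hydrogen therefore gives the lower number at both nitrogens, and that second nitrogen now has an order of hydrogen, then methyl, then oxetan-3-yl.

Going by these compounds, how an ethyl group or a longer chain would behave on either nitrogen remains open. Nothing available explains these shifts.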